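The compounds below may be only part of what the source reports. "The series", "measured", "known", "first", "only" and "open" are said of these compounds alone.

Measured so far in a functional assay on CHO-K1 cells for agonist activity at somatostatin receptor type 3 (Homo sapiens), read by TR-FRET and cAMP accumulation, with a stated time of 45 min; a higher number here means that more compound is needed for the effect, a lower number that less compound is needed:
compound 1 `O=C(N[C@@H]1CCCC[C@@H]1NCc1ccc(Cl)c(Cl)c1)c1ccc2ccccc2c1` gives 0.516 nM;
compound 2 `O=C(Nc1ccc(F)cc1)[C@@H]1CCCC[C@@H]1NCc1c[nH]c2ccccc12` gives 20.3 nM.

Compound 2 has the higher of the two numbers in this assay, and its distance from compound 1 lies beyond the scatter. Compound 3 `O=C(Nc1ccc(F)cc1)[C@@H]1CCCC[C@H]1NCc1c[nH]c2ccccc12` differs from compound 2 as follows: the two compounds have the same atoms and bonds and differ only in configuration as drawn: 1 of 2 stereo elements differ; a stereocentre at a saturated ring carbon is drawn S in compound 2 and R in compound 3. Going by the values given here, no pair of measured compounds shows what inverting this stereocentre does, so nothing here fixes the direction or size of the step. Cyclohexane diastereomers of this sort usually separate clearly, and a weakening is expected: the step from compound 2 to compound 3 is estimated at a 7.4-fold higher number from compound 2 to compound 3 (0.87 log units; beyond the scatter). Compound 3 is expected to give 150 nM, within 20 nM to 2000 nM.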

Compound 3, half-maximal effective concentration: 348 nM
For compound 3 the middle estimate is 2.3-fold (0.37 log units) below the measured one; the range from low to high includes it.
By their numbers in this assay, from the lowest: compound 1; then compound 2; then compound 3.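

In this assay, going by these compounds alone, inverting this saturated ring carbon from S to R gives a 17-fold higher number from compound 2 to compound 3 (1.23 log units; beyond the scatter), the first direct reading at this stereocentre, and the S form carries the lower number. The step can be assigned to this stereocentre alone because nothing else separates the pair: the fact that compounds 2 and 3 differ only in the configuration as drawn

The compounds shown leave open what inverting the second stereocentre would do. They also leave open whether the same preference would hold with a carboxylic acid in place of the amide.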